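Methoxy in place of nitro: what to expect

The source may hold more compounds than are shown below. What is called first, only, known or untested is meant among the compounds shown, and "the series" means these compounds.

In a functional assay on cells (Homo sapiens) for cytotoxicity, read by MTT assay, with a stated time of 24 h (a lower number here means a stronger inhibitor, a higher number a weaker inhibitor), compound 1 `CCCCCCCCCCCCCCNC(=O)[C@H](CO)/N=C/c1cccc(C)c1` gives 82900 nM and compound 2 `CCCCCCCCCCCCCCNC(=O)[C@H](CO)/N=C/c1ccccc1[N+](=O)[O-]` gives 21700 nM as the lower of the two numbers. Compound 3 `CCCCCCCCCCCCCCNC(=O)[C@H](CO)/N=C/c1ccccc1OC` is still unmeasured and has methoxy in place of nitro on an aromatic carbon. For the measured compounds named here, only one measured step bears on this, and only indirectly: a 3.8-fold lower number from compound 1 to compound 2 (0.58 log units; beyond the scatter) came with 2-nitrophenyl in place of 3-methylphenyl. Going by the values given here, no measured compound carries methoxy, so the direction is uncertain. With compound 1 at 82900 nM as the only other reference, a small move to a higher number in this assay is expected, no larger than that measured step. The estimate amounts to a 2.1-fold higher number from compound 2 to compound 3 (0.32 log units; beyond the scatter) as the expected step. For compound 3 the estimated value is 45000 nM with an expected range of 15000 nM to 110000 nM around it.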

Compound 3, half-maximal inhibitory concentration: 12500 nM
Compound 3: middle estimate off by 3.6-fold (0.56 log units), on the high side; the measured number lies below the stated range.
By their numbers in this assay, from the lowest: compounds 3 and 2 (each within the scatter of the next); then compound 1.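

In this assay, nitro and methoxy on this aromatic carbon, ortho to a large group, cannot be told apart: the swap gives a 1.7-fold lower number from compound 2 to compound 3 (0.24 log units; within the scatter), even though the two groups differ in heavy atoms and hydrogen-bond acceptors. The earlier compounds shown here left open whether the gain seen with 2-nitrophenyl needed nitro itself, and compound 3 shows that a different group keeps the number clearly away from that of compound 1, with a 6.6-fold lower number from compound 1 to compound 3 (0.82 log units; beyond the scatter). Nothing available explains why these two groups read alike.

Compound 1 differs from the other two in both the group and its place on the ring, so the roles of those two changes remain unseparated. A 2-methylphenyl group would help to divide them, and an amine or a carboxylic acid on the same carbon would test how far the tolerance for different groups extends.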